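Chain extension at the oxygen substituent of compound 1

The compounds below may be only part of what the source reports. "The series", "measured", "known", "first", "only" and "open" are said of these compounds alone.

Compound 1 `CCCOCNc1n[n+]([O-])c2cc(OC)ccc2[n+]1[O-]` sits second highest of the three numbers in a functional assay on PC-3 cells (Homo sapiens) for cytotoxicity, read by MTT assay, with a stated time of 72 h (a higher number here means a weaker inhibitor, a lower number a stronger inhibitor), giving 6570 nM. Its nearest neighbour is compound 2 `[O-][n+]1nc(NCOC2CCCCC2)[n+]([O-])c2ccccc21`, which gives 3250 nM; furthest away is compound 3 `CCCOCNc1n[n+]([O-])c2ccccc2[n+]1[O-]`, which gives 14200 nM. The two measured steps are a 2.2-fold higher number from compound 1 to compound 3 (0.33 log units; beyond the scatter) and a 4.4-fold higher number from compound 2 to compound 3 (0.64 log units; beyond the scatter).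

Compound 4 `CCCCCOCNc1n[n+]([O-])c2cc(OC)ccc2[n+]1[O-]` keeps the methoxy core of compound 1 and differs only by ethyl in place of hydrogen on a saturated chain carbon, three bonds along the chain from an oxygen on a saturated carbon. Going by the values given here, of the measured steps, only the one from compound 2 to compound 3 touches the group on the oxygen, and there the smaller propyl group carried the higher number, a 4.4-fold higher number from compound 2 to compound 3 (0.64 log units; beyond the scatter), while the ring-substituent step is not at issue here. Lengthening the chain from propyl to pentyl is not the same change as swapping in cyclohexyl, so only a modest shift in this assay is expected, towards a lower number.

For compound 4 the estimate is 3800 nM in this assay, with a range of 1800 nM to 8000 nM, which means an expected step of a 1.7-fold lower number from compound 1 to compound 4 (0.24 log units; within the scatter).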

Compound 4, half-maximal inhibitory concentration: 3630 nM
Compound 4: middle estimate off by 1.0-fold (0.02 log units), on the high side, within the range that was stated.
By their numbers in this assay, from the lowest: compounds 2, 4 and 1 (each within the scatter of the next, the first and the last beyond it); then compound 3.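

Going by these compounds alone, compound 4 gives the first reading of chain length on the oxygen of the methoxy core: pentyl in place of propyl comes with a 1.8-fold lower number from compound 1 to compound 4 (0.26 log units; within the scatter) in this assay and so leaves the two compounds indistinguishable in this assay. The earlier step at this oxygen, a 4.4-fold higher number from compound 2 to compound 3 (0.64 log units; beyond the scatter) on the core without methoxy, exchanged cyclohexyl and propyl and lay beyond the scatter, so the two steps describe different changes on different cores and do not form a trend. No measurement on hand explains the reading at this position.

Going by these compounds, a longer chain such as octyl, or a propyl chain ending in an amine or a carboxylic acid, remains open at this oxygen. Also open, on these data alone, is whether the step of a 2.2-fold higher number from compound 1 to compound 3 (0.33 log units; beyond the scatter) carries over to pentyl or cyclohexyl on the oxygen.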